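The source may hold more compounds than are shown below. What is called first, only, known or untested is meant among the compounds shown, and "the series" means these compounds.

Working notes on the series. Going by the values given here, in a functional assay on MDA-MB-231 cells (Homo sapiens) for cytotoxicity, read by MTT assay, with a stated time of 24 h (a lower number here means a stronger inhibitor, a higher number a weaker inhibitor), compound 1 (`Cc1ccc(/C=C2\CN(Cc3cn(Cc4ccc(F)cc4)nn3)C/C(=C\c3ccc(C)cc3)C2=O)cc1`) gives 26800 nM, the lowest of the three numbers so far. Compound 3 (`COc1ccc(/C=C2\CN(Cc3cn(Cc4ccc(F)cc4)nn3)C/C(=C\c3ccc(OC)cc3)C2=O)cc1`) gives 70700 nM, the nearest value, and compound 2 (`Cc1ccc(/C=C2\CN(C(=S)SCc3cn(Cc4ccccc4F)nn3)C/C(=C\c3ccc(C)cc3)C2=O)cc1`) gives 91500 nM, the furthest. Both gaps lie beyond the scatter.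

Compound 4 (`Cc1ccc(/C=C2\CN(Cc3cn(Cc4ccccc4F)nn3)C/C(=C\c3ccc(C)cc3)C2=O)cc1`) has not yet been measured in this assay. Its structure departs from that of compound 1 in one place: 2-fluorophenyl in place of 4-fluorophenyl on a saturated chain carbon bound to an aromatic nitrogen. In words, 2-fluorophenyl stands in place of 4-fluorophenyl on a saturated chain carbon bound to an aromatic nitrogen. Among the compounds with values here, no pair of measured compounds differs in only one place, so the series offers no direct guide to the size of this step. Compound 2 also carries 2-fluorophenyl, but its structure differs from that of compound 4 elsewhere as well, so its value is only weak evidence.

A small move toward a weaker number is expected, probably not beyond the scatter: the estimate is a 1.2-fold higher number from compound 1 to compound 4 (0.09 log units; within the scatter). For compound 4, the expected value is 33000 nM, with an estimated range of 14000 nM to 80000 nM.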

Compound 4, half-maximal inhibitory concentration: 10000 nM
Beside the measured number, compound 4's estimate is 3.3-fold (0.52 log units) above it; measured number below the stated range.
By their numbers in this assay, from the lowest: compound 4; then compound 1; then compounds 3 and 2 (each within the scatter of the next).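

In this assay, going by these compounds alone, 2-fluorophenyl in place of 4-fluorophenyl on a saturated chain carbon bound to an aromatic nitrogen gives a 2.7-fold lower number from compound 1 to compound 4 (0.43 log units; beyond the scatter), the first step that can be read between compounds differing in one place. The two groups have the same atoms and the same counts, so this position responds to where the fluorine stands on the ring, even with the composition unchanged, and the step runs toward the stronger side of the assay. Nothing measured here accounts for the size or direction of this step.

From the compounds shown here alone, whether an unsubstituted phenyl or a 2-chlorophenyl at this place would go further in the same direction remains open. Also open, going by these compounds, is whether the step carries over to the core of compound 3, which bears methoxy groups.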